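Methoxy for Chloro: Estimating Compound 4

The source may report more compounds than this note shows. Statements on the series, on what has been measured and on what is new or still open speak of the compounds shown alone.

Compound 1 `O=C(Nc1cccc(Cl)c1)Nc1nnc(Sc2ncnc3scc(-c4ccncc4)c23)s1`: 43900 nM
Compound 2 `O=C(Nc1ccc(F)cc1)Nc1nnc(Sc2ncnc3scc(-c4ccncc4)c23)s1`: 18900 nM
Compound 3 `O=C(Nc1ccc(Cl)c(C(F)(F)F)c1)Nc1nnc(Sc2ncnc3scc(-c4ccncc4)c23)s1`: 28000 nM

Three compounds share one core and differ only in the aryl group on an amide-type nitrogen. In a functional assay on T47D cells (Homo sapiens) for antiproliferative activity, read by MTT assay, with a stated time of 48 h (a lower number here means a stronger inhibitor, a higher number a weaker inhibitor), compound 1 gives the highest number of the three; compound 3 sits nearest, and the gap a 1.6-fold lower number from compound 1 to compound 3 (0.20 log units; within the scatter) is within the scatter, while the gap a 2.3-fold lower number from compound 1 to compound 2 (0.37 log units; beyond the scatter) is beyond it, so only compound 2 is clearly distinguishable from compound 1.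

Compound 4 `COc1cccc(NC(=O)Nc2nnc(Sc3ncnc4scc(-c5ccncc5)c34)s2)c1` carries the change (methoxy in place of chloro on an aromatic carbon). Among the compounds with values here, no measured step exchanges one group for another at this place; the steps from compound 1 to compound 2 and to compound 3 change the aryl group elsewhere and give modest or negligible movement. They suggest that varying this ring shifts this assay little. A small lowering or none beyond the scatter is therefore expected for compound 4, as a 1.5-fold lower number from compound 1 to compound 4 (0.17 log units; within the scatter). The estimate for compound 4 is 30000 nM, with a range from 12000 nM to 75000 nM.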

Compound 4, half-maximal inhibitory concentration: 56900 nM
The estimate for compound 4 lay 1.9-fold (0.28 log units) below the measured number; the measured number falls inside the stated range.
By their numbers in this assay, from the lowest: compounds 2, 3, 1 and 4 (each within the scatter of the next, the first and the last beyond it).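

In this assay, within the data shown here, the exchange of chloro for methoxy is the first change seen at this exact place on the ring, and it moves the number only within the scatter (a 1.3-fold higher number from compound 1 to compound 4 (0.11 log units; within the scatter)). The 3-methoxyphenyl group of compound 4 can therefore not be told apart from the 3-chlorophenyl group of compound 1, yet it stands clear of the other two aryl groups, by modest steps (a 2.0-fold higher number from compound 3 to compound 4 (0.31 log units; beyond the scatter); a 3.0-fold higher number from compound 2 to compound 4 (0.48 log units; beyond the scatter)). No measurement at hand offers a reason for these differences.

From the compounds shown here alone, with only chloro and methoxy seen at this place, it remains open whether an amine or a carboxylic acid there would shift the number beyond the scatter. A longer chain, such as ethoxy or butoxy, is likewise an open case.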